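The source may hold more compounds than are shown below. What is called first, only, known or untested is meant among the compounds shown, and "the series" means these compounds.

Of the compounds shown here, two have so far been tested in a functional assay on C6 cells (Rattus norvegicus) for inhibition, read by sulforhodamine B assay, with a stated time of 72 h; a lower number here means that less compound is needed, a higher number that more compound is needed for the effect. Compound 1, `CCC(=O)Oc1cccc2ccc(/C=C/c3ccccc3[N+](=O)[O-])nc12`, gives 6300 nM. Compound 2, `CSc1ccc(C(=O)/C=C/c2ccc([N+](=O)[O-])o2)cc1`, gives 1600 nM. Compound 2 therefore holds the lower of the two numbers, and its gap to compound 1 is wide enough to lie beyond the usual scatter of repeated measurements of this kind. Compound 3, `O=C(/C=C/c1ccc([N+](=O)[O-])o1)c1ccc(-n2ccnc2)cc1`, has not yet been measured. It differs from compound 2 in one place: 1H-imidazol-1-yl in place of methylsulfanyl on an aromatic carbon. For the measured compounds named here, no pair of measured compounds shows what this particular change does, so the size of the step can only be estimated. The expected step is a 1.6-fold higher number from compound 2 to compound 3 (0.19 log units; within the scatter), toward a somewhat higher number, close to the edge of the scatter. Compound 3 is estimated at 2500 nM, with a likely range from 800 nM to 8000 nM.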

Compound 3, half-maximal effective concentration: 3500 nM
Estimate against measurement, compound 3: 1.4-fold (0.15 log units) below; the range from low to high includes it.
By their numbers in this assay, from the lowest: compound 2; then compounds 3 and 1 (each within the scatter of the next).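

In this assay, for the compounds shown here, putting 1H-imidazol-1-yl in place of methylsulfanyl on this aromatic carbon, para to a large group, gives a 2.2-fold higher number from compound 2 to compound 3 (0.34 log units; beyond the scatter) and provides the first measured step at this position. The number at this position therefore does depend on the group attached, although the shift is only modest for a swap from a group with no ring to one carrying a five-membered aromatic ring. Nothing available here accounts for the direction or size of this step.

As far as these compounds go, it remains open whether the step follows from the ring as a whole or from its nitrogen atoms, which a phenyl ring or a simple amine at the same place could help to separate. Seen only once, this change also says nothing yet about its size on another core.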